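Trading the Nitrophenyl of Compound 2 for Difluorophenyl

A few compounds are considered here, and "the series" means these few. Any claim that something is new, unique, unknown or untested is made for them only; others in the source may bear on it.

Compound 1 `CCN(CC)Cc1c(O)c([C@H]2CCN(C)C[C@H]2O)c2oc(C)cc(=O)c2c1O`: 47%
Compound 2 `Cc1oc2c([C@H]3CCN(C)C[C@H]3O)c(O)cc(O)c2c(=O)c1C(O)c1ccc([N+](=O)[O-])cc1`: 0%

In a functional assay on HL-60 cells (Homo sapiens) for inhibition, read by MTT assay, with a stated time of 48 h, tested at 10 uM (on this read-out higher numbers stand for more inhibition of growth at the one concentration tested and lower numbers for less inhibition of growth), compound 2 gives 0%, the lowest of the two numbers, while compound 1 gives 47%, a gap beyond the scatter. Compound 3 `Cc1oc2c([C@H]3CCN(C)C[C@H]3O)c(O)cc(O)c2c(=O)c1C(O)c1cc(F)cc(F)c1` differs from compound 2 by 3,5-difluorophenyl in place of 4-nitrophenyl on a saturated chain carbon bound to an aromatic carbon and an oxygen on a saturated carbon. Going by the values given here, no measured pair shows this change, so the step in this assay is expected to be small, toward more inhibition, and not clearly beyond the scatter: a number 10 percentage points higher from compound 2 to compound 3 (within the scatter). Compound 3 is therefore expected to give 10%, within a range from 0% to 35%.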

Compound 3, percent growth inhibition at one concentration: 30%
The estimate for compound 3 lay 20 percentage points below the measured number; measured number inside the range.
By their numbers in this assay, from the lowest: compound 2; then compound 3; then compound 1.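

In this assay, 3,5-difluorophenyl in place of 4-nitrophenyl on this saturated chain carbon gives a number 30 percentage points higher from compound 2 to compound 3 (beyond the scatter), so the aryl group at this place affects growth inhibition. The hydroxy-bearing carbon can therefore carry an aryl group with measurable inhibition, and the reading of compound 2 is not set by the rest of the structure alone. Nothing measured here explains the step. Still open, going by these compounds, is how an unsubstituted phenyl, a pyridine ring or a carboxylic acid-bearing phenyl would read on the same carbon. Also open, on these data alone, is whether both fluorines are needed for this gain.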